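This account rests on a few compounds, and the source may have more. Where it says the series, first, only, none or still open, it means among the compounds named here.

In an in vitro ADME assay on microsomes from liver (Homo sapiens) for metabolic stability, using NADPH (a higher number here means faster removal of the compound, a lower number slower removal), compound 1 (`CC(C)(CO)CNC(=O)c1cc2cc(C#N)ccc2n1Cc1cccc(OC(F)(F)F)c1`) gives 62 mL.min-1.g-1 and compound 2 (`COc1ccc(Br)cc1Cn1c(C(=O)NCC(C)(C)CO)cc2cc(C#N)ccc21`) gives 104 mL.min-1.g-1, two values within the scatter of each other. Compound 3 (`Cc1ccc(Cl)cc1Cn1c(C(=O)NCC(C)(C)CO)cc2cc(C#N)ccc21`) carries 5-chloro-2-methylphenyl in place of the 5-bromo-2-methoxyphenyl of compound 2, on a saturated chain carbon bound to an aromatic nitrogen: 5-chloro-2-methylphenyl in place of 5-bromo-2-methoxyphenyl on a saturated chain carbon bound to an aromatic nitrogen. Among the compounds with values here, no measured pair isolates such a change. Compound 1 at 62 mL.min-1.g-1 and compound 2 at 104 mL.min-1.g-1 differ at this same place yet stay within the scatter, so no step beyond the scatter is expected. The expected step is a 1.2-fold lower number from compound 2 to compound 3 (0.06 log units; within the scatter). For compound 3 the estimated value is 90 mL.min-1.g-1, with an expected range of 50 mL.min-1.g-1 to 160 mL.min-1.g-1.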

Compound 3, intrinsic clearance in microsomes: 119 mL.min-1.g-1
Compound 3: the middle estimate sits 1.3-fold (0.12 log units) below what was measured; measured number inside the range.
By their numbers in this assay, from the lowest: compounds 1, 2 and 3 (each within the scatter of the next).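

In this assay the exchange gives a 1.1-fold higher number from compound 2 to compound 3 (0.06 log units; within the scatter) and so stays within the scatter. On a saturated chain carbon bound to an aromatic nitrogen, 5-chloro-2-methylphenyl thus takes the place of 5-bromo-2-methoxyphenyl with no step beyond the scatter, even with the hydrogen-bond acceptor of the leaving group gone. Nothing shown accounts for this reading.

Going by these compounds, whether an amine or a carboxylic acid on this phenyl ring would move the number beyond the scatter stays open. The bromine-to-chlorine and methoxy-to-methyl exchanges come together in this pair, so neither can be read alone.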